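The source may hold more compounds than are shown below. What is called first, only, known or untested is meant among the compounds shown, and "the series" means these compounds.

Compound 1 `CCOC(=O)[C@@H]1CCCN(S(=N)(=O)c2ccc(S(=O)(=O)N(CC)CC)cc2)C1`, compound 2 `CCOC(=O)[C@@H]1CCCN(S(=O)(=O)c2ccc(S(=O)(=O)N3CCOCC3)cc2)C1` and compound 3 `CCN(CC)S(=O)(=O)c1ccc(S(=O)(=O)N2CCC[C@@H](C(=O)N(C)C(C)C)C2)cc1` share a core carrying two sulfonyl groups and differ at the ring-bound carbonyl. In a functional assay on MIA PaCa-2 cells (Homo sapiens) for inhibition, read by MTT assay, with a stated time of 3 days (a lower number here means a stronger inhibitor, a higher number a weaker inhibitor), compound 1 gives 4700 nM, compound 2 gives 4100 nM and compound 3 gives 1400 nM, the lowest of the three numbers, with both other values above it by more than the usual scatter. Compound 4 `CCN(CC)S(=O)(=O)c1ccc(S(=O)(=O)N2CCC[C@@H](C(=O)NC3CN(C(=O)OC(C)(C)C)C3)C2)cc1` has not been measured; it differs from compound 3 in one place: (1-(tert-butoxycarbonyl)azetidin-3-yl)amino in place of isopropyl(methyl)amino on a carbonyl carbon. Going by the values given here, no comparable step among the measured compounds exists, so the direction is uncertain; a modest change in either direction, or none beyond the scatter, is expected, giving a 1.3-fold higher number from compound 3 to compound 4 (0.11 log units; within the scatter). Compound 4 is thus estimated at 1800 nM, within 600 nM to 5500 nM.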

Compound 4, half-maximal inhibitory concentration: 100 nM
Estimate against measurement, compound 4: 18-fold (1.26 log units) above; measured number outside the range, below it.
By their numbers in this assay, from the lowest: compound 4; then compound 3; then compounds 2 and 1 (each within the scatter of the next).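

In this assay, (1-(tert-butoxycarbonyl)azetidin-3-yl)amino in place of isopropyl(methyl)amino on a carbonyl carbon gives a 14-fold lower number from compound 3 to compound 4 (1.15 log units; beyond the scatter), the only single-place change shown here. What sits on this carbonyl carbon can therefore move the number strongly, and a much larger group is accepted there. No measured evidence explains this step. From the compounds shown here alone, it remains open whether the tert-butoxycarbonyl group, the four-membered ring or the amide hydrogen carries the step. Methylamino, or azetidin-3-ylamino with a free ring amine, on that carbonyl carbon would help separate these parts.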